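A few compounds are considered here, and "the series" means these few. Any claim that something is new, unique, unknown or untested is made for them only; others in the source may bear on it.

Two compounds share one core: compound 1, `O=[N+]([O-])c1ccc(COc2ccc(Nc3ncnc4cc5c(cc34)OCCOCCO5)cc2)cc1`, and compound 2, `FC(F)(F)c1ccc(COc2cccc(Nc3ncnc4cc5c(cc34)OCCOCCOCCO5)c2)cc1`. In a functional assay on MCF7 cells (Homo sapiens) for antiproliferative activity, read by MTT assay, with a stated time of 72 h (on this read-out lower numbers stand for stronger inhibition and higher numbers for weaker inhibition), compound 1 gives 39700 nM, while in this assay compound 2 gives 17600 nM, the lower of the two numbers. Compound 3, `O=[N+]([O-])c1ccc(COc2cccc(Nc3ncnc4cc5c(cc34)OCCOCCOCCO5)c2)cc1`, has not yet been measured. It differs from compound 2 by nitro in place of trifluoromethyl on an aromatic carbon. Compound 1 also holds a nitro group, but it differs from compound 2 in more than one place, so no single step can be read from that pair. A modest move toward a higher number is expected: a 1.4-fold higher number from compound 2 to compound 3 (0.15 log units; within the scatter). Compound 3 is estimated at 25000 nM, within 8000 nM to 80000 nM.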

Compound 3, half-maximal inhibitory concentration: > 100000 nM
Compound 3 was reported as a limit; the forecaster's own chance of this, stated with the estimate: 10%; middle value at least 4.0-fold (0.60 log units) away from the limit.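

Among the compounds shown here, exchanging 4-(trifluoromethyl)benzyl for 4-nitrobenzyl gives the first comparison here that differs in only one place, and in this assay it brings an at least 5.6-fold higher number from compound 2 to compound 3 (0.75 log units; beyond the scatter). This position, para to a large group, therefore responds to the group it carries, with trifluoromethyl giving the lower number of this pair. Compound 3 is recorded only as a limit, not as a number: the limit of > 100000 nM in this assay, at which 1 of the 3 values shown sits.

From the compounds shown here alone, how an amine or a nitrile at this position would compare remains open. So does whether this exchange would have a similar effect on the core of compound 1.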